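Carbamate in place of cyclopentyl amide on the piperidine

A few compounds are considered here, and "the series" means these few. Any claim that something is new, unique, unknown or untested is made for them only; others in the source may bear on it.

The series shares one core, carried by compound 1 `CCNC(=O)Nc1sc2ccccc2c1C(=O)N1CCN(C2CCN(C(=O)C3CCCC3)CC2)CC1` and compound 2 `CCNC(=O)Nc1sc2ccccc2c1C(=O)N1CCN(C2CCN(C(=O)OC(C)(C)CF)CC2)CC1`, which differ only at the carbonyl carbon attached to the amide-type nitrogen in the ring. In a functional assay on HepG2 cells (Homo sapiens) for inhibition, read by scintillation counting, with a stated time of 2 h (a lower number here means a stronger inhibitor, a higher number a weaker inhibitor), compound 1 gives 309 nM, the highest of the two numbers recorded, and compound 2 gives 61 nM. Among the compounds with values here, the step of a 5.1-fold lower number from compound 1 to compound 2 (0.70 log units; beyond the scatter) is the only measured step available, and it shows that replacing the five-membered carbon ring with an acyclic oxygen-bearing group on that carbonyl carbon moves the number down beyond the scatter.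

Compound 3 `CCNC(=O)Nc1sc2ccccc2c1C(=O)N1CCN(C2CCN(C(=O)OC(C)(C)C(F)(F)F)CC2)CC1` is not yet measured. Relative to compound 1 the change is 1-methyl-1-(trifluoromethyl)ethoxy in place of cyclopentyl on a carbonyl carbon. The relevant comparison is the measured step of a 5.1-fold lower number from compound 1 to compound 2 (0.70 log units; beyond the scatter), since compound 3 carries the same kind of acyclic oxygen-linked branched group on the same carbonyl carbon, differing from compound 2 only in the fluorine count of that group. A step of similar size and direction is therefore expected for compound 3, about a 3.9-fold lower number from compound 1 to compound 3 (0.59 log units; beyond the scatter). In this assay compound 3 is expected to give 80 nM, with a range from 30 nM to 250 nM.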

Compound 3, half-maximal inhibitory concentration: 81 nM
Estimate against measurement, compound 3: 1.0-fold (0.01 log units) below; the measured number falls inside the stated range.
By their numbers in this assay, from the lowest: compounds 2 and 3 (each within the scatter of the next); then compound 1.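

The step of a 3.8-fold lower number from compound 1 to compound 3 (0.58 log units; beyond the scatter) in this assay gives a second case, after compound 2, in which an acyclic oxygen-linked group in place of cyclopentyl on the carbonyl carbon lowers the number beyond the scatter, so that change no longer rests on a single pair. The step of a 1.3-fold higher number from compound 2 to compound 3 (0.12 log units; within the scatter) shows that trifluoromethyl in place of fluoromethyl on that group makes no readable difference here, and compound 2 and compound 3 cannot be ordered in this assay. No supporting measurement bears on why either group differs from cyclopentyl.

The compounds shown do not separate the contributions of the oxygen link, the loss of the ring and the fluorine atoms, and a fluorine-free tert-butoxy group on the same carbonyl carbon would be needed to isolate the role of fluorine. As far as these compounds go, how an amine or a longer chain at this place would read in this assay also remains open, as does whether the same steps would hold on a different core.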